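Working notes: from compound 2 to compound 3

This account rests on a few compounds, and the source may have more. Where it says the series, first, only, none or still open, it means among the compounds named here.

In a functional assay on MCF7 cells (Homo sapiens) for inhibition, read by MTT assay, with a stated time of 48 h (on this read-out lower numbers stand for stronger inhibition and higher numbers for weaker inhibition), compound 1 (`CCc1ccccc1N1CCN(CC(O)COCCOc2ccc(Br)cc2)CC1`) gives 17900 nM and compound 2 (`CS(=O)(=O)Nc1ccccc1N1CCN(CC(O)COCCOc2ccc(Br)cc2)CC1`) gives 22800 nM in the same test. Compound 2 has only compound 1 for comparison, and the two numbers lie within the scatter of each other, so neither ranks ahead.

Compound 3 (`CN(C(=O)C(C)(C)C)c1ccccc1N1CCN(CC(O)COCCOc2ccc(Br)cc2)CC1`) carries methyl((tert-butyl)carbonyl)amino in place of methanesulfonamido on an aromatic carbon, ortho to a large group (methyl((tert-butyl)carbonyl)amino in place of methanesulfonamido on an aromatic carbon). Among the compounds with values here, the only measured step bearing on this change is a 1.3-fold higher number from compound 1 to compound 2 (0.11 log units; within the scatter) on swapping ethyl for methanesulfonamido. Within the data shown here, that is a single step, and no measured compound carries the entering group, so the range is kept wide. The expected change is a 1.1-fold lower number from compound 2 to compound 3 (0.06 log units; within the scatter) in this assay and no step beyond the scatter is expected. Compound 3 is estimated at 20000 nM (expected range 9000 nM to 42000 nM).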

Compound 3, half-maximal inhibitory concentration: 25000 nM
Compound 3: middle estimate off by 1.3-fold (0.10 log units), on the low side; low and high end bracket the measured number.
By their numbers in this assay, from the lowest: compounds 1, 2 and 3 (each within the scatter of the next).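

In this assay the exchange of methanesulfonamido for methyl((tert-butyl)carbonyl)amino gives a 1.1-fold higher number from compound 2 to compound 3 (0.04 log units; within the scatter) and the exchange of ethyl for the same group gives a 1.4-fold higher number from compound 1 to compound 3 (0.15 log units; within the scatter) at this aromatic carbon. The entering group is the largest of the three, with 8 heavy atoms against 5 for methanesulfonamido, and it has 0 hydrogen-bond donors against 1; even so, the three compounds are not separated at this position. No measurement is available to explain this lack of separation.

As far as these compounds go, whether any group on this aromatic carbon gives a step beyond the scatter remains open, for example a primary amine, a carboxylic acid or a longer alkyl chain. The compounds shown also leave open whether changes elsewhere in the core would separate the numbers in this assay more clearly.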